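Half-life after swapping back to a five-membered aromatic ring

A few compounds are considered here, and "the series" means these few. Any claim that something is new, unique, unknown or untested is made for them only; others in the source may bear on it.

Three compounds of the series have been run in an ADME assay on microsomes from liver (Rattus norvegicus) for metabolic stability; a higher number here means that the compound lasts longer, a lower number that the compound disappears faster. Compound 1 `CC(C)C(Nc1nccs1)c1ccc(-c2ccc3cccc(F)c3c2)[nH]c1=O` gives 0.07 h. Compound 2 `CC(C)C(/C=C1\CCNC1=O)c1ccc(-c2ccc3cccc(F)c3c2)[nH]c1=O` gives 0.345 h, and compound 3 `CC(C)C(c1ccc(-c2ccc3cccc(F)c3c2)[nH]c1=O)N1CCN/C1=N\C#N` gives 0.327 h. Compound 3 thus stands second highest of the three; the gap a 1.1-fold lower number from compound 2 to compound 3 (0.02 log units; within the scatter) is within the scatter, while the gap a 4.7-fold higher number from compound 1 to compound 3 (0.67 log units; beyond the scatter) is beyond it.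

Compound 4 `Cc1nc(C(c2ccc(-c3ccc4cccc(F)c4c3)[nH]c2=O)C(C)C)[nH]c1C` is the next step from compound 3: a group of 7 heavy atoms (5 carbon, 2 nitrogen; one five-membered aromatic ring with 2 hetero atoms) in place of a group of 8 heavy atoms (4 carbon, 4 nitrogen; one five-membered non-aromatic ring with 2 hetero atoms), on a saturated chain carbon bound to an aromatic carbon and a saturated chain carbon. The two steps that bear on it, a 4.9-fold higher number from compound 1 to compound 2 (0.69 log units; beyond the scatter) and a 4.7-fold higher number from compound 1 to compound 3 (0.67 log units; beyond the scatter), each exchanged a five-membered aromatic ring with 2 hetero atoms at the same place for a five-membered non-aromatic ring and raised the half-life by a modest amount. The present change puts a five-membered aromatic ring with 2 hetero atoms back at that place, though a different one, so a modest fall is expected, not necessarily as large.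

The half-life of compound 4 is estimated at 0.12 h, with a range of 0.05 h to 0.3 h. The expected step is a 2.7-fold lower number from compound 3 to compound 4 (0.44 log units; beyond the scatter).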

Compound 4, half-life: 0.0733 h
Compound 4: the middle estimate sits 1.6-fold (0.21 log units) above what was measured; the range from low to high includes it.
By their numbers in this assay, from the lowest: compounds 1 and 4 (each within the scatter of the next); then compounds 3 and 2 (each within the scatter of the next).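

In this assay, 4,5-dimethyl-1H-imidazol-2-yl on this saturated chain carbon costs half-life against both non-aromatic ring groups (a 4.5-fold lower number from compound 3 to compound 4 (0.65 log units; beyond the scatter) and a 4.7-fold lower number from compound 2 to compound 4 (0.67 log units; beyond the scatter)), so a five-membered aromatic ring with 2 hetero atoms gives a low number here even without the amino link of (1,3-thiazol-2-yl)amino. Within the data shown here, the two aromatic ring groups also sit level (a 1.0-fold higher number from compound 1 to compound 4 (0.02 log units; within the scatter)), so across these four compounds the half-life splits by ring type, with compounds 1 and 4 low, compounds 2 and 3 higher, and no compound against the split. Nothing at hand accounts for this split.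

From the compounds shown here alone, it remains open whether the two methyl groups contribute, which an unsubstituted imidazol-2-yl would address. Also open, going by these compounds, is whether the higher half-life extends to a six-membered morpholine ring or an open-chain amine at this place.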